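This account rests on a few compounds, and the source may have more. Where it says the series, first, only, none or still open, it means among the compounds named here.

Of the compounds shown here, three have been tested in a functional assay on HEK293 cells for activation of 5-hydroxytryptamine receptor 4 (Homo sapiens), read by cAMP accumulation; a lower number here means a smaller maximal response, a higher number a larger maximal response. Compound 1 `CCCCCN1CCC(NC(=O)c2cc(Cl)c(N)cc2OC)CC1` reaches > 100% in this assay, which is a limit of the assay and not a number. Compound 2 `COc1cc(N)c(Cl)cc1C(=O)NC1CCN(CCCCCCCCO)CC1` differs from it by 3-hydroxypropyl in place of hydrogen on a saturated chain carbon, five bonds along the chain from an amine nitrogen in a ring, and the resulting step that the two limits leave unreadable from compound 1 to compound 2 cannot be read. Compound 2 likewise sits at the limit, giving > 100% in this assay. Within the data shown here, compound 3 `COc1cc(N)c(Cl)cc1C(=O)NC1CCN(CCCCCCCCN2C(=O)c3ccccc3C2=O)CC1` gives 89% in this assay, so that a number at least 11 percentage points lower from compound 2 to compound 3 (beyond the scatter) is the only readable step. Since (the limit of > 100% in this assay, at which 2 of the 3 values shown sit), compound 2 is known only as lying at the limit.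

Compound 4 `COc1cc(N)c(Cl)cc1C(=O)NC1CCN(CCCCCN2CCCCC2)CC1` differs from compound 2 by piperidin-1-yl in place of 3-hydroxypropyl on a saturated chain carbon, five bonds along the chain from an amine nitrogen in a ring. Among the measured compounds shown here, the one measured step that bears on the chain end, a number at least 11 percentage points lower from compound 2 to compound 3 (beyond the scatter), shows that a larger replacement there can lower the maximal response, while compound 1 shows that a plain chain end also reaches the limit. For compound 4 a small drop or none beyond the scatter is therefore expected. Compound 4 is estimated at 95% in this assay, between 80% and 110%. This estimate corresponds to an expected step of a number at least 5 percentage points lower from compound 2 to compound 4 (that floor lies within the scatter).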

Compound 4, intrinsic activity: the largest response reached, in percent of the reference agonist's: > 100%
Compound 4 gave a limit, no number (the forecaster's own chance of this, stated with the estimate: 40%); middle value at least 5 percentage points away from the limit.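

Compound 4 reaches > 100% in this assay, which is a limit of the assay and not a number. Its steps from compound 1 and from compound 2 therefore cannot be read: the limit of > 100% in this assay, at which 3 of the 4 values shown sit.

The compounds shown leave open how far the maximal responses of compound 1, compound 2 and compound 4 lie apart, and whether piperidin-1-yl and 3-hydroxypropyl differ at all at this place on the chain.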